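The compounds below may be only part of what the source reports. "The series", "measured", "known", "first", "only" and "open" are said of these compounds alone.

Compound 1 `CCCc1nc(C(C)(C)O)c(C(=O)OCCCCCCC(=O)OCC)n1Cc1ccc(-c2ccccc2C2=NNNN2)cc1`: 81.1%
Compound 2 `CCCc1nc(C(C)(C)O)c(C(=O)NCCNCCO)n1Cc1ccc(-c2ccccc2C2=NNNN2)cc1`: 98.9%

In an ADME assay on a cell-free system (plasma, Rattus norvegicus, strain Sprague-Dawley) for metabolic stability, with a stated time of 30 min, tested at 50 mg/mL (on this read-out lower numbers stand for a less stable compound and higher numbers for a more stable compound), compound 1 gives 81.1%, the lower of the two measured numbers, while compound 2 gives 98.9%. Compound 3 `CCCc1nc(C(C)(C)O)c(C(=O)NCCCCCCC(=O)O)n1Cc1ccc(-c2ccccc2C2=NNNN2)cc1` differs from compound 1 in one place: (6-carboxyhexyl)amino in place of (6-(ethoxycarbonyl)hexyl)oxy on a carbonyl carbon. Going by the values given here, one measured step bears on this change: a number 17.8 percentage points higher from compound 1 to compound 2 (beyond the scatter), where the same group left and an amino-linked chain entered. A step upward of similar size is therefore expected for compound 3, although the number cannot rise much beyond that of compound 2. Compound 3 is expected to reach 94% (range 84% to 100%), an expected step of a number 12.9 percentage points higher from compound 1 to compound 3 (beyond the scatter).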

Compound 3, percent of the compound remaining: 97.5%
Beside the measured number, compound 3's estimate is 3.5 percentage points below it, and the stated range covers the measured number.
By their numbers in this assay, from the lowest: compound 1; then compounds 3 and 2 (each within the scatter of the next).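

The rise seen with compound 2 is not tied to one particular chain: (6-carboxyhexyl)amino on the same carbonyl carbon also gives a number 16.4 percentage points higher from compound 1 to compound 3 (beyond the scatter) and so replaces the ester-linked chain of compound 1 with a similar outcome. The two amino-linked chains cannot be told apart on this read-out, with a number 1.4 percentage points lower from compound 2 to compound 3 (within the scatter) even though one ends in a carboxylic acid and the other in a hydroxyl group. Compound 3 changes both the link and the chain end, so a (6-carboxyhexyl)oxy group, an oxygen-linked chain ending in a carboxylic acid, would show which of the two matters. What lies behind these numbers stays unexplained, with no supporting measurement available.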